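The source may hold more compounds than are shown below. What is called first, only, known or untested is meant among the compounds shown, and "the series" means these compounds.

The set holds three measured compounds built on a shared core. Compound 1 `C[C@H]1CC[C@@H]2[C@@H](OC(=O)[C@]23CC(c2ccccc2)=NO3)[C@]2(C)C(=O)C=C[C@@]12O` gives, in a physicochemical assay for lipophilicity (on this read-out lower numbers stand for lower lipophilicity and higher numbers for higher lipophilicity), a value of 1.41. Compound 2 `Cc1ccc(C2=NO[C@]3(C2)C(=O)O[C@@H]2[C@H]3CC[C@H](C)[C@]3(O)C=CC(=O)[C@@]23C)cc1` gives 1.86 in this assay, and the step of a number 0.45 log units higher from compound 1 to compound 2 (beyond the scatter) shows what one extra methyl on an aromatic carbon does on this read-out. Compound 3 `Cc1ccccc1C1C[C@@]2(ON1c1ccccc1)C(=O)O[C@@H]1[C@H]2CC[C@H](C)[C@]2(O)C=CC(=O)[C@@]12C` gives 3.64 in this assay, the highest of the three numbers; compound 2 lies nearest to it and compound 1 furthest, both beyond the scatter.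

Compound 4 `C[C@H]1CC[C@@H]2[C@@H](OC(=O)[C@]23CC(c2ccc([N+](=O)[O-])cc2)N(c2ccccc2)O3)[C@]2(C)C(=O)C=C[C@@]12O` has not yet been measured. Compared with compound 3 its change is 4-nitrophenyl in place of 2-methylphenyl on a saturated ring carbon. Among the compounds with values here, only one measured step bears on this change, and only partly: the step from compound 1 to compound 2 concerns a methyl on an aromatic carbon, and compound 4 loses such a methyl. Within the data shown here, no measured pair shows what a nitro group on an aromatic ring does in this assay. Since the methyl step was modest and the entering nitrophenyl carries two hydrogen-bond acceptors where the leaving methylphenyl carried none, a drop is expected rather than a rise. For compound 4 an estimated step of a number 0.74 log units lower from compound 3 to compound 4 (beyond the scatter) is expected in this assay. Compound 4 is therefore estimated at 2.9, with a range from 2.3 to 3.5.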

Compound 4, partition coefficient: 3.15
For compound 4 the middle estimate is 0.25 log units below the measured one; the range from low to high includes it.
By their numbers in this assay, from the lowest: compound 1; then compound 2; then compound 4; then compound 3.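

In this assay, within the data shown here, exchanging 2-methylphenyl for 4-nitrophenyl on the saturated ring carbon next to the ring nitrogen gives a number 0.49 log units lower from compound 3 to compound 4 (beyond the scatter), the only measured step at this position. The earlier compounds shown here showed a change only on an aromatic carbon, with a number 0.45 log units higher from compound 1 to compound 2 (beyond the scatter), and the new step is also modest but runs in the opposite direction. It belongs to the exchange as a whole, so it cannot be divided between the loss of the 2-methylphenyl group and the entry of the 4-nitrophenyl group, and no measurement shown accounts for it.

The compounds shown leave open what a plain phenyl group at this ring carbon would give, a comparison that would set the methyl and the nitro group apart from the aromatic ring that carries them. They also leave open whether an amine or a carboxylic acid on that aromatic ring would move the read-out further, and whether the same exchange would give a similar step if the phenyl group on the ring nitrogen were replaced by a longer alkyl chain.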